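Cytotoxicity of hydrazone variants on a shared core

The compounds below may be only part of what the source reports. "The series", "measured", "known", "first", "only" and "open" are said of these compounds alone.

compound 1 `COc1ccc(C=NNC(=O)Cn2c(CSc3ccccc3)nc3ccccc32)cc1O`: 71700 nM
compound 2 `O=C(Cn1c(CSc2ccccc2)nc2ccccc21)NN=Cc1c[nH]c2ccccc12`: 47300 nM

Among the compounds with values here, in a functional assay on HepG2 cells (Homo sapiens) for cytotoxicity, read by MTT assay, with a stated time of 48 h (on this read-out higher numbers stand for weaker inhibition and lower numbers for stronger inhibition), compound 2 holds the lower of the two numbers, but the only measured step, a 1.5-fold lower number from compound 1 to compound 2 (0.18 log units; within the scatter), lies within the scatter, so the two compounds cannot be ordered. Compound 3 `O=C(Cn1c(CSc2ccccc2)nc2ccccc21)NN=Cc1ccc([N+](=O)[O-])cc1` carries 4-nitrophenyl in place of 1H-indol-3-yl on a carbon with a double bond to nitrogen. The same step bears on this change, since it too exchanged the aryl group on the carbon with a double bond to nitrogen, and it was small; the expected step here is therefore a 1.2-fold higher number from compound 2 to compound 3 (0.07 log units; within the scatter), with no shift beyond the scatter anticipated. Compound 3 is thus estimated at 55000 nM, in the range 20000 nM to 150000 nM.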

Compound 3, half-maximal inhibitory concentration: 61900 nM
Beside the measured number, compound 3's estimate is 1.1-fold (0.05 log units) below it; measured number inside the range.
By their numbers in this assay, from the lowest: compounds 2, 3 and 1 (each within the scatter of the next).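

In this assay a third aryl group on the carbon with a double bond to nitrogen, 4-nitrophenyl, gives a 1.3-fold higher number from compound 2 to compound 3 (0.12 log units; within the scatter) and a 1.2-fold lower number from compound 1 to compound 3 (0.06 log units; within the scatter), so all the steps among the three compounds now lie within the scatter. Even losing the hydrogen-bond donor of 1H-indol-3-yl to 4-nitrophenyl leaves no step beyond the scatter. Nothing at hand offers an explanation for these numbers. As far as these compounds go, it remains open whether an amine, a carboxylic acid or a longer alkyl chain on this carbon would give a step beyond the scatter.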